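The source may hold more compounds than are shown below. What is called first, only, known or untested is meant among the compounds shown, and "the series" means these compounds.

The measured compounds:

Compound 1, `Nc1ccccc1NC(=O)c1ccc(CSC(=S)N2CCN(Cc3ccncc3)CC2)cc1`: in a functional assay on A-375 cells (Homo sapiens) for antiproliferative activity, read by CCK-8 assay, with a stated time of 72 h, tested at 8 uM (on this read-out lower numbers stand for a weaker effect and higher numbers for a stronger effect at the one concentration tested), compound 1 gives 89.5%.
Compound 2, `Nc1ccccc1NC(=O)c1ccc(CSC(=S)N(Cc2ccccc2)Cc2ccccc2)cc1`: in this assay compound 2 gives 32.5%.
Compound 3, `COC(=O)c1ccc2c(c1)CCN2C(=S)SCc1ccc(C(=O)Nc2ccccc2N)cc1`: in this assay compound 3 gives 79.2%.

Compound 1 stands highest of the three numbers in this assay. Its nearest neighbour is compound 3, whose number lies below it by more than the usual scatter, and compound 2 lies far below, so compound 1 is the strongest of the measured set. Compound 4, `Cc1ccc(N2CCN(C(=S)SCc3ccc(C(=O)Nc4ccccc4N)cc3)CC2)cc1`, has not yet been measured. It differs from compound 1 in one place: 4-methylphenyl in place of (pyridin-4-yl)methyl on an amine nitrogen in a ring. Within the data shown here, no pair of measured compounds differs in a single place, so nothing sets the size of this step directly. The three values do show that the group attached to the shared core moves the read-out over a wide span, from compound 2 up to compound 1. Given this spread, the step of a number 19.5 percentage points lower from compound 1 to compound 4 (beyond the scatter) is expected to be downward and beyond the scatter. Compound 4 is estimated at 70%, with a range from 40% to 90%.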

Compound 4, a percentage reported as inhibition, at one concentration (the size of the read-out at that concentration, not a potency): 26.4%
Estimate against measurement, compound 4: 43.6 percentage points above, outside the stated range (below it).
By their numbers in this assay, from the lowest: compounds 4 and 2 (each within the scatter of the next); then compound 3; then compound 1.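

In this assay, 4-methylphenyl in place of (pyridin-4-yl)methyl on this amine nitrogen in a ring gives a number 63.1 percentage points lower from compound 1 to compound 4 (beyond the scatter), a large step and the first direct measure of how much this position matters. The two groups have the same count of heavy atoms, and each holds one six-membered aromatic ring and no net charge, so matching these counts does not preserve the read-out at this position. No measurement shown explains the drop.

This single step changes the ring nitrogen, the hydrogen-bond acceptor count and the way the ring is attached all at once, and it cannot separate them. Phenylmethyl or pyridin-4-yl on the same nitrogen would address that question, and the compounds shown leave it open.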